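Fluoro for nitro on the benzamide ring of compound 3

The source may hold more compounds than are shown below. What is called first, only, known or untested is meant among the compounds shown, and "the series" means these compounds.

The measured compounds:
Compound 1, `CN1CCC2C(CCCC2NC(=O)c2ccccc2)C1`: 101 umol/kg
Compound 2, `CN1CCC2C(CCCC2NC(=O)c2ccc(Cl)cc2)C1`: 49 umol/kg
Compound 3, `CN1CCC2C(CCCC2NC(=O)c2ccc([N+](=O)[O-])cc2)C1`: 95 umol/kg

In a functional assay on the whole organism (heart) with Mus musculus as the target (a lower number here means that less compound is needed, a higher number that more compound is needed for the effect), compound 3 stands second highest of the three numbers, nearest to compound 1 and furthest from compound 2, both gaps within the scatter. Compound 4, `CN1CCC2C(CCCC2NC(=O)c2ccc(F)cc2)C1`, differs from it in one place: fluoro in place of nitro on an aromatic carbon. Going by the values given here, two measured steps bear on this. The step of a 1.9-fold higher number from compound 2 to compound 3 (0.29 log units; within the scatter) shows that exchanging the nitro group for a halogen stays within the scatter, while a 2.1-fold lower number from compound 1 to compound 2 (0.31 log units; beyond the scatter) shows a chloro group giving a modest lowering against hydrogen. A fluoro group is therefore expected to give at most a modest lowering in this assay, a 1.4-fold lower number from compound 3 to compound 4 (0.13 log units; within the scatter). Compound 4 is estimated at 70 umol/kg, with a range from 35 umol/kg to 140 umol/kg.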

Compound 4, dose for half-maximal effect: 110 umol/kg
Compound 4: the middle estimate sits 1.6-fold (0.20 log units) below what was measured, and the stated range covers the measured number.
By their numbers in this assay, from the lowest: compounds 2, 3, 1 and 4 (each within the scatter of the next, the first and the last beyond it).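

In this assay the fluoro group does not repeat what chloro does at this position (a 2.2-fold higher number from compound 2 to compound 4 (0.35 log units; beyond the scatter)), so the two halogens cannot be treated as interchangeable here. Fluoro stays within the scatter of both nitro (a 1.2-fold higher number from compound 3 to compound 4 (0.06 log units; within the scatter)) and hydrogen (a 1.1-fold higher number from compound 1 to compound 4 (0.04 log units; within the scatter)), which leaves chloro as the only group set apart from hydrogen or fluoro, though not from nitro. No evidence is available that accounts for this difference between the halogens. Going by these compounds, whether a bromo, methoxy or amine group at this position would follow chloro or fluoro remains open.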